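This account rests on a few compounds, and the source may have more. Where it says the series, first, only, none or still open, it means among the compounds named here.

Measured so far in a functional assay with Alpha-1D adrenergic receptor (Homo sapiens) as the target, read by calcium flux; on this read-out lower numbers stand for smaller maximal responses and higher numbers for larger maximal responses:
compound 1 `CCn1ccc(-c2ccccc2NCC2=NCCN2)n1`, 0%
compound 2 `Cn1cccc1-c1ccccc1NCC1=NCCN1`, 32%
compound 3 `CCCn1nccc1-c1ccccc1NCC1=NCCN1`, 0%

Compound 3 stands level with compound 1 at the digits shown, the two together at the bottom of the three numbers. Its nearest neighbour is compound 1, with no change within the scatter; its furthest is compound 2, whose number lies higher, beyond the scatter. Compound 4 `CC(C)n1nccc1-c1ccccc1NCC1=NCCN1` has not been measured. It differs from compound 3 by isopropyl in place of propyl on an aromatic nitrogen. Within the data shown here, no pair of measured compounds shows this change, so the step has no precedent here. For compound 4 no step beyond the scatter is expected in this assay; the estimated step is no change at the digits printed from compound 3 to compound 4 (within the scatter). Compound 4 is expected at 0%, with a range from 0% to 20%.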

Compound 4, largest response reached (reported as maximal response), in percent of the reference or control that the assay uses: 0%
Compound 4: middle estimate and measured number agree at the digits printed, and the stated range covers the measured number.
By their numbers in this assay, from the lowest: compounds 1, 3 and 4 (each within the scatter of the next); then compound 2.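

In this assay isopropyl in place of propyl on an aromatic nitrogen brings no change at the digits printed from compound 3 to compound 4 (within the scatter) and gives the first read at this position: branched and straight chains of the same atoms stand together here. With compound 3 at 0% and compound 4 at 0% there is no response left to fall, so this step could not show a loss. No measurement at hand explains the result. Still open, from the compounds shown here alone, is whether any group at this position can raise the response, for example a cyclopropyl ring, a butyl chain or a chain carrying an amine.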